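A few compounds are considered here, and "the series" means these few. Any claim that something is new, unique, unknown or untested is made for them only; others in the source may bear on it.

Measured so far:
compound 1 `COc1ccccc1-c1nnc(-c2sc(-c3cccnc3)nc2C)o1` — in an ADME assay on HCT-116 cells (Homo sapiens) for cytotoxicity, read by MTT assay (a lower number here means that less compound is tolerated, a higher number that more compound is tolerated), compound 1 gives > 100 ug/mL, a limit.
compound 2 `Cc1nc(-c2cccnc2)sc1-c1nnc(-c2ccncc2)o1` — in this assay compound 2 gives > 100 ug/mL, a limit.

Compound 2 stands at the limit of this assay. Compound 1 sits there too. The step that the two limits leave unreadable from compound 1 to compound 2 is therefore unreadable. Compound 3 `Cc1nc(-c2cccnc2)sc1-c1nnc(-c2cccnc2)o1` differs from compound 2 by pyridin-3-yl in place of pyridin-4-yl on an aromatic carbon. Going by the values given here, no measured step bears on this change. Both values shown sit at the limit (the limit of > 100 ug/mL in this assay, at which 2 of the 2 values shown sit), so no step beyond the scatter is anticipated. Compound 3 is expected at 120 ug/mL (range 60 ug/mL to 300 ug/mL). The expected step is a step that the limit leaves unreadable from compound 2 to compound 3, and a limit rather than a number is the likely report.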

Compound 3, half-maximal cytotoxic concentration: > 100 ug/mL
Compound 3 gave a limit, no number; the forecaster's own chance of this, stated with the estimate: 85%; the middle value lies beyond the limit too.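

In this assay compound 3 gives > 100 ug/mL, a limit. Going by these compounds alone, no step among compound 1, compound 2 and compound 3 can be read: the limit of > 100 ug/mL in this assay, at which 3 of the 3 values shown sit. The compounds shown leave open whether pyridin-3-yl, pyridin-4-yl and 2-methoxyphenyl differ at all in this assay.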